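Swapping an aryl for a benzyl group on a piperazine

The compounds below may be only part of what the source reports. "The series", "measured", "known", "first", "only" and "open" are said of these compounds alone.

Measured compounds:
Compound 1, `CCCn1c(=O)c2[nH]c(-c3ccc(S(=O)(=O)N4CCN(c5ccc(Cl)cc5)CC4)cc3)nc2n(CC)c1=O`: 4.31 nM
Compound 2, `CCCn1c(=O)[nH]c2nc(-c3ccc(S(=O)(=O)N4CCN(c5ccccc5Cl)CC4)cc3)[nH]c2c1=O`: 0.403 nM

Both numbers come from an assay on CHO cells for displacement of a labelled ligand from adenosine receptor A2b (Homo sapiens), read by scintillation counting, with a stated time of 75 min, in the presence of a further agent that is not named here; a lower number here means a stronger inhibitor, a higher number a weaker inhibitor. Compound 2 gives the lower of the two values; compound 1 gives a higher one, and the gap between them lies beyond the usual scatter of repeated measurements. The two compounds differ in more than one place, so nothing can be said about which part of the structure accounts for that gap.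

Compound 3, `CCCn1c(=O)[nH]c2nc(-c3ccc(S(=O)(=O)N4CCN(Cc5cccc(Br)c5)CC4)cc3)[nH]c2c1=O`, has not yet been measured in this assay. It differs from compound 2 at one position only: 3-bromobenzyl in place of 2-chlorophenyl on an amine nitrogen in a ring. Going by the values given here, no measured pair shows a change of this kind, so the direction and size of its effect are not known from these data. A change of modest size is expected, possibly toward a higher number. Compound 3 is therefore expected to give about 1.5 nM in this assay, within a range from 0.3 nM to 8 nM. The step of a 3.7-fold higher number from compound 2 to compound 3 (0.57 log units; beyond the scatter) that this estimate means is a guess rather than a reading of a shown trend.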

Compound 3, inhibition constant: 0.148 nM
Compound 3: middle estimate off by 10-fold (1.01 log units), on the high side, and the stated range ends above it.
By their numbers in this assay, from the lowest: compound 3; then compound 2; then compound 1.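

In this assay, going by these compounds alone, replacing 2-chlorophenyl with 3-bromobenzyl on the ring amine nitrogen gives a 2.7-fold lower number from compound 2 to compound 3 (0.44 log units; beyond the scatter) and provides the first reading of a single change at this position. The nitrogen therefore accepts a benzyl group in place of a directly attached phenyl without any loss of binding, and the result is a modest gain, although the swap alters the link to the aromatic ring, the halogen and its place on that ring all at once. Nothing measured here explains this gain.

On these data alone, it remains open which of those three alterations carries the step, and plain benzyl or 3-chlorobenzyl would help to separate them. Also open, as far as these compounds go, is how this nitrogen responds to a group with no aromatic ring, such as cyclohexyl, or to a chain ending in a carboxylic acid.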